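A few compounds are considered here, and "the series" means these few. Any claim that something is new, unique, unknown or untested is made for them only; others in the source may bear on it.

Measured compounds in a functional assay on the whole organism with Rattus norvegicus as the target, with a stated time of 4 h, at a dose of 40 mg/kg by the intraperitoneal route; on this read-out lower numbers stand for less inhibition and higher numbers for more inhibition at the one dose given (going by the name of the read-out):
- compound 1 `CSCc1c(C)nc2c(OCc3ccccc3)cccn12` gives 29%
- compound 2 `Cc1nc2c(OCc3ccccc3)cccn2c1CS(C)(=O)=O` gives 61%
- compound 3 `Cc1nc2c(OCc3ccccc3)cccn2c1Cl` gives 93%

Compound 3 stands highest of the three numbers in this assay; its nearest neighbour is compound 2, and compound 1 lies furthest below it, both gaps beyond the scatter. The measured steps are all large: a number 32 percentage points higher from compound 1 to compound 2 (beyond the scatter), a number 64 percentage points higher from compound 1 to compound 3 (beyond the scatter) and a number 32 percentage points higher from compound 2 to compound 3 (beyond the scatter). Each of these exchanges a sulfur-bearing chain for another group or for a halogen; none of them exchanges one halogen for another.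

Compound 4 `Cc1nc2c(OCc3ccccc3)cccn2c1Br` differs from compound 3 by one change: bromo in place of chloro on an aromatic carbon. Within the data shown here, no measured step bears directly on a swap of chloro for bromo on this aromatic carbon. The shared core, the methyl group and the benzyloxy part are untouched. Among the measured compounds shown here, with no step of this kind on record, the working expectation is a number close to that of compound 3.

The expected step is a number 5 percentage points lower from compound 3 to compound 4 (within the scatter), which is to say none beyond the scatter.

Compound 4 is therefore estimated at 88%, with a range from 70% to 99%.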

Compound 4, a percentage reported as inhibition, in the whole organism at one dose (the size of the read-out at that dose, not a potency): 26%
The estimate for compound 4 lay 62 percentage points above the measured number, and the stated range ends above it.
By their numbers in this assay, from the lowest: compounds 4 and 1 (each within the scatter of the next); then compound 2; then compound 3.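

On the aromatic carbon of the five-membered ring, next to the ring nitrogen, the identity of the halogen decides the outcome in this assay: bromo in place of chloro gives a number 67 percentage points lower from compound 3 to compound 4 (beyond the scatter) even though the heavy-atom and hydrogen-bond counts stay the same. The comparison with the sulfur-bearing chains also changes, with a number 35 percentage points lower from compound 2 to compound 4 (beyond the scatter) against (methylsulfonyl)methyl and a number 3 percentage points lower from compound 1 to compound 4 (within the scatter) against (methylsulfanyl)methyl, so the advantage over both chains seen for chloro does not extend to halogens in general. Nothing on hand accounts for the gap between the two halogens.

From the compounds shown here alone, whether chloro is a lone high point at this carbon stays open, and fluoro, iodo, an amine or a nitrile there would test this. Also open, going by these compounds, is whether the gap between compound 3 and compound 4 persists at other doses and times.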